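The compounds below may be only part of what the source reports. "The series", "measured", "known", "first", "only" and "open" are said of these compounds alone.

Measured compounds:
- Compound 1 `CC(C)C(c1ncc[nH]1)c1ccc(-c2ccc3cccc(F)c3c2)[nH]c1=O`. In an ADME assay on microsomes from liver (Rattus norvegicus) for metabolic stability (a lower number here means that the compound disappears faster, a higher number that the compound lasts longer), compound 1 gives < 0.0667 h, which is a limit of the assay rather than a number.
- Compound 2 `CCn1ncc2c(F)cc(-c3ccc(C(CC)(CC)c4nnc(C)[nH]4)c(=O)[nH]3)cc21`. In this assay compound 2 gives > 3 h, again a limit of the assay.
- Compound 3 `CC(C)C(/C=C1\CCNC1=O)c1ccc(-c2ccc3cccc(F)c3c2)[nH]c1=O`. In this assay compound 3 gives 0.345 h.

For the measured compounds named here, compound 3 thus holds the only actual number in this set; the other two results are limits, one at each end, as the limit of < 0.0667 h in this assay, at which 1 of the 3 values shown sits, and the limit of > 3 h in this assay, at which 1 of the 3 values shown sits, show. Going by the values given here, the single measured step is an at least 5.1-fold higher number from compound 1 to compound 3 (0.71 log units; beyond the scatter), and because the limit of < 0.0667 h in this assay, at which 1 of the 3 values shown sits, marks the starting point, its true size is only known as a minimum.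

Compound 4 `CC(C)C(/C=C1/CCNC1=O)c1ccc(-c2ccc3cccc(F)c3c2)[nH]c1=O` is the next compound. Compared with compound 3 the change is the two compounds have the same atoms and bonds; at least one stereo element is drawn with a configuration in one of them and without one in the other: 1 of 2 stereo elements differ; a double bond is drawn E in compound 3 and Z in compound 4. Among the compounds with values here, no measured step touches the geometry of this double bond: the one step known swaps a whole ring for another, which is a different kind of change. There is therefore no basis for expecting a shift beyond the scatter, and the expected step is a 1.0-fold higher number from compound 3 to compound 4 (0.01 log units; within the scatter). Compound 4 is accordingly estimated at 0.35 h, with a plausible range from 0.15 h to 0.8 h.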

Compound 4, half-life: 0.06 h
The estimate for compound 4 lay 5.8-fold (0.77 log units) above the measured number; measured number below the stated range.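

In this assay, the geometry of one double bond counts on its own: with the same atoms and bonds on both sides, the result is a 5.8-fold lower number from compound 3 to compound 4 (0.76 log units; beyond the scatter). The earlier readable step at this position exchanged one whole ring for another, so it could not show that the five-membered non-aromatic ring with its carbonyl also gives different numbers when it only changes from the E to the Z arrangement on the same double bond. One caution applies to reading this as a clean comparison of two fully defined compounds: the fact that one of compounds 3 and 4 is drawn with a defined configuration and the other without, at the place where they differ

As far as these compounds go, the step between the two rings with the Z double bond cannot be read, since compound 1 stands at a limit of the assay rather than at a number: the limit of < 0.0667 h in this assay, at which 1 of the 4 values shown sits. Whether E and Z differ in the same way with another group on this double bond, such as a carboxylic acid or an open-chain amide in place of the five-membered ring, stays open.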